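Pyrazoline series: compound 2 to compound 4

A few compounds are considered here, and "the series" means these few. Any claim that something is new, unique, unknown or untested is made for them only; others in the source may bear on it.

Measured in an assay on isolated protein for inhibition of protein kinase C zeta type (Homo sapiens), with a stated time of 4 min, tested at 62.5 uM; a lower number here means less inhibition, a higher number more inhibition at the concentration tested (going by the name of the read-out):
- compound 1, `CC(C)(C)C1=NN(c2ccc(F)cc2)C(c2ccc(O)cc2)C1`: 95.5%
- compound 2, `CC(C)(C)C1=NN(c2ccc(Br)cc2)C(c2ccc(O)cc2)C1`: 93.2%
- compound 3, `CC(C)(C)C1=NN(c2ccc(C(=O)O)cc2)C(c2ccc(O)cc2)C1`: 47.9%

Compound 2 stands second highest of the three; its nearest neighbour is compound 1, with a number 2.3 percentage points lower from compound 1 to compound 2 (within the scatter), while compound 3 lies far off, with a number 45.3 percentage points lower from compound 2 to compound 3 (beyond the scatter). Compound 4 is `CC(C)(C)C1=NN(c2ccccc2F)C(c2ccc(O)cc2)C1`; the change is 2-fluorophenyl in place of 4-bromophenyl on an amine nitrogen in a ring. Going by the values given here, no measured step bears directly on this change: the halogen swap a number 2.3 percentage points lower from compound 1 to compound 2 (within the scatter) lies within the scatter, and the large drops a number 47.6 percentage points lower from compound 1 to compound 3 (beyond the scatter) and a number 45.3 percentage points lower from compound 2 to compound 3 (beyond the scatter) concern a carboxy group, not a halogen. Both halogen-bearing compounds inhibit strongly, so compound 4 is expected to stay high, with a step of a number 8.2 percentage points lower from compound 2 to compound 4 (within the scatter) at most modest. Compound 4 is estimated at 85%, between 55% and 98%.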

Compound 4, a percentage reported as inhibition, at one concentration (the size of the read-out at that concentration, not a potency): 57.6%
Compound 4: the middle estimate sits 27.4 percentage points above what was measured; the range from low to high includes it.
By their numbers in this assay, from the lowest: compounds 3 and 4 (each within the scatter of the next); then compounds 2 and 1 (each within the scatter of the next).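

The place of the fluoro group on this phenyl ring matters: the change from 4-fluorophenyl to 2-fluorophenyl on the amine nitrogen in the ring gives a number 37.9 percentage points lower from compound 1 to compound 4 (beyond the scatter). The step of a number 35.6 percentage points lower from compound 2 to compound 4 (beyond the scatter) is also large, so carrying a halogen at this position does not by itself keep inhibition high, which compounds 1 and 2 alone could not show. No available evidence bears on the reason for this drop.

Still open, on these data alone, is whether 2-bromophenyl would behave like 2-fluorophenyl. Also open, as far as these compounds go, is how 2-methoxyphenyl or 2-aminophenyl would read on the same nitrogen.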